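The source may report more compounds than this note shows. Statements on the series, on what has been measured and on what is new or still open speak of the compounds shown alone.

In a functional assay on K562 cells (Homo sapiens) for antiproliferative activity, read by MTT assay, with a stated time of 6 days (on this read-out lower numbers stand for stronger inhibition and higher numbers for weaker inhibition), compound 1 `CC(=O)O[C@@H]1C=CC(=O)O[C@@H]1[C@@H](COC(=O)c1ccc(Cl)cc1)OC(C)=O` gives 3690 nM and stands highest of the three measured compounds. Compound 2 `O=C1C=C[C@@H](OCc2ccccc2)[C@@H]([C@@H](COC(=O)/C=C/c2ccccc2)OCc2ccccc2)O1` gives 1590 nM and compound 3 `O=C1C=C[C@@H](OCc2ccccc2)[C@@H]([C@@H](COC(=O)/C=C/c2ccc([N+](=O)[O-])cc2)OCc2ccccc2)O1` gives 1270 nM and both lie beyond the scatter from compound 1. Compound 4 `CC(=O)OC[C@@H](OC(C)=O)[C@H]1OC(=O)C=C[C@H]1OC(C)=O` differs from compound 1 by methyl in place of 4-chlorophenyl on a carbonyl carbon and so holds acetyl where compound 1 holds (4-chlorophenyl)carbonyl. For the measured compounds named here, the one measured step (a 1.3-fold lower number from compound 2 to compound 3 (0.10 log units; within the scatter)) is nitro in place of hydrogen on an aromatic carbon. Going by the values given here, that is another kind of change, and no measured pair tests the loss of 4-chlorophenyl. The expectation therefore rests on compound 1 at 3690 nM as the closest reference, with a slight lean towards a higher number and no firm expectation of a step beyond the scatter. The expected step is small (a 1.4-fold higher number from compound 1 to compound 4 (0.13 log units; within the scatter)) and uncertain. For compound 4 the estimated value is 5000 nM within an expected range from 1800 nM to 14000 nM in this assay on this reasoning.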

Compound 4, half-maximal inhibitory concentration: 7540 nM
Estimate against measurement, compound 4: 1.5-fold (0.18 log units) below; the range from low to high includes it.
By their numbers in this assay, from the lowest: compounds 3 and 2 (each within the scatter of the next); then compound 1; then compound 4.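

For the compounds shown here, replacing 4-chlorophenyl with methyl on this carbonyl carbon gives a 2.0-fold higher number from compound 1 to compound 4 (0.31 log units; beyond the scatter) in this assay and is the first measured change at this position, showing that the number responds to this group, though only modestly. The 4-chlorophenyl group is not needed for a measurable read-out, as compound 4 still gives 7540 nM in this assay with acetyl in its place. No measurement shown here accounts for the direction or size of this step.

The compounds shown leave open whether the chlorine or the aromatic ring carries the difference, as a plain phenyl group on the same carbonyl carbon would separate the two. They also leave open how an amine or a longer alkyl chain would read at this position.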